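A few compounds are considered here, and "the series" means these few. Any claim that something is new, unique, unknown or untested is made for them only; others in the source may bear on it.

Measured so far in an ADME assay on PBMC cells (Homo sapiens) for cytotoxicity; a higher number here means that more compound is tolerated, a lower number that less compound is tolerated:

Compound 1, `COC(=O)N[C@@H](CSC(C)(C)C)C(=O)N1CCC[C@H]1c1ncc(-c2ccc(-c3ccc(-c4cnc([C@@H]5CCCN5C(=O)[C@@H](NC(=O)OC)C(C)C)[nH]4)cc3)cc2)[nH]1`: 18000 nM
Compound 2, `COC(=O)N[C@@H](CCSC)C(=O)N1CCC[C@H]1c1ncc(-c2ccc(-c3ccc(-c4cnc([C@@H]5CCCN5C(=O)[C@@H](NC(=O)OC)C(C)C)[nH]4)cc3)cc2)[nH]1`: 41000 nM

Among the measured compounds shown here, compound 2 stands highest of the two numbers in this assay; its nearest neighbour is compound 1, and the only recorded step, a 2.3-fold higher number from compound 1 to compound 2 (0.36 log units; beyond the scatter), is modest but beyond the scatter.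

The next compound in the series is compound 3, `COC(=O)N[C@@H](CS(=O)(=O)Cc1ccccc1)C(=O)N1CCC[C@H]1c1ncc(-c2ccc(-c3ccc(-c4cnc([C@@H]5CCCN5C(=O)[C@@H](NC(=O)OC)C(C)C)[nH]4)cc3)cc2)[nH]1`. Relative to compound 2 the change is benzylsulfonyl in place of (methylsulfanyl)methyl on a saturated chain carbon, two bonds along the chain from an amide-type nitrogen and a carbonyl carbon. For the measured compounds named here, the only measured step that touches this site is the one from compound 1 to compound 2, where a smaller sulfur-bearing group gave a higher number. Compound 3 moves the other way, to a larger group with an added ring and two further acceptors, so the evidence is thin and points, if anywhere, toward a number somewhat below that of compound 2. The expected step is therefore a 1.6-fold lower number from compound 2 to compound 3 (0.21 log units; within the scatter), a modest drop, though a result within the scatter of compound 2 would not surprise. The estimate for compound 3 in this assay is 25000 nM, with a range from 10000 nM to 60000 nM.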

Compound 3, half-maximal cytotoxic concentration: 21000 nM
Compound 3: middle estimate off by 1.2-fold (0.08 log units), on the high side; measured number inside the range.
By their numbers in this assay, from the lowest: compounds 1, 3 and 2 (each within the scatter of the next, the first and the last beyond it).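

In this assay, benzylsulfonyl, with 10 heavy atoms and a six-membered aromatic ring, replaces (methylsulfanyl)methyl, with 3 heavy atoms, on the saturated chain carbon and gives a 2.0-fold lower number from compound 2 to compound 3 (0.29 log units; within the scatter) for this much larger group. Replacing (tert-butyl)sulfanyl at the same place gives a 1.2-fold higher number from compound 1 to compound 3 (0.07 log units; within the scatter) as the second reading, so compound 3 cannot be separated from either neighbour, even though compound 1 and compound 2 are separated from each other; at this position, in these three compounds, adding the ring and the sulfonyl produces no step beyond the scatter. No supporting measurement bears on the reason for this result.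

The compounds shown do not separate the contribution of the ring from that of the sulfonyl: benzylsulfanyl or methylsulfonyl at this place would each change only one of the two. Going by these compounds, it also remains open whether sulfur matters here at all, a question that a plain butyl chain, or a chain ending in an amine or a carboxylic acid, would address.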